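Chloro in place of iodo in a growth inhibitor

The compounds below may be only part of what the source reports. "The series", "measured", "known", "first", "only" and "open" are said of these compounds alone.

In a functional assay on cells (Cancer cell lines, Homo sapiens) for inhibition (on this read-out higher numbers stand for weaker inhibition of growth and lower numbers for stronger inhibition of growth), compound 1 (`Nc1ccc(-c2nc3ccc(F)cc3s2)cc1I`) gives < 10 nM as its result, a limit of the assay and not a number. Compound 2 (`Nc1ccc(-c2nc3cc(F)ccc3s2)cc1`) gives 11500 nM as a measured number in this assay and so shows far weaker inhibition of growth. Compound 3 (`Nc1ccc(-c2nc3ccc(F)cc3s2)cc1Cl`) has chloro in place of iodo on an aromatic carbon of a six-membered aromatic ring of carbon only, ortho to an amino group (chloro in place of iodo on an aromatic carbon) and otherwise matches compound 1. Within the data shown here, no step between measured compounds that differ in one place is available, so the expectation rests on this single change. In this assay the expected step that the limit leaves unreadable from compound 1 to compound 3 is small and not clearly beyond the usual scatter, leaning if anything toward weaker inhibition. For compound 3 the estimated value is 8 nM with an expected range from 1 nM to 60 nM in this read-out.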

Compound 3, concentration for 50% growth inhibition: < 10 nM
Compound 3 gave a limit, no number; the forecaster's own chance of this, stated with the estimate: 60%; the middle value is on the limit's open side.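

No step can be read from compound 1 to compound 3, chloro in place of iodo on an aromatic carbon, because both results are limits and not numbers: the limit of < 10 nM in this assay, at which 2 of the 3 values shown sit. The compounds shown leave open whether this change alters growth inhibition at all, and by how much.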